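Swapping Propylamino for Dimethylamino on Compound 1

The compounds below may be only part of what the source reports. "The series", "measured", "known", "first", "only" and "open" are said of these compounds alone.

In a functional assay on SW480 cells (Homo sapiens) for inhibition, read by luminescence and resazurin assay, with a stated time of 3 days (on this read-out lower numbers stand for stronger inhibition and higher numbers for weaker inhibition), compound 1 (`CCCNc1nc(NCc2ccc(C(=O)NCc3ccc(F)cc3)cc2)c2cc(C)ccc2n1`) gives 2200 nM as its measured value. Compound 2 (`CCCNc1nc(NCc2ccc(C(=O)Nc3ccc(Cl)nc3)cc2)c2cc(C)ccc2n1`) gives 2100 nM in the same test and compound 3 (`CCCNc1nc(NCc2ccc(C(=O)Nc3ccc(F)cc3)cc2)c2cc(C)ccc2n1`) gives 1300 nM there. The two steps of a 1.0-fold lower number from compound 1 to compound 2 (0.02 log units; within the scatter) and a 1.7-fold lower number from compound 1 to compound 3 (0.23 log units; within the scatter) both stay within the scatter, so compound 1 cannot be told apart from either neighbour.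

Compound 4 (`Cc1ccc2nc(N(C)C)nc(NCc3ccc(C(=O)NCc4ccc(F)cc4)cc3)c2c1`) keeps the amide end of compound 1 and carries dimethylamino in place of propylamino (dimethylamino in place of propylamino on an aromatic carbon) on an aromatic carbon between two ring nitrogen atoms. Among the measured compounds shown here, no measured step touches this position, since all of them alter the group on the amide nitrogen. They offer only indirect guidance: the steps of a 1.0-fold lower number from compound 1 to compound 2 (0.02 log units; within the scatter) and a 1.7-fold lower number from compound 1 to compound 3 (0.23 log units; within the scatter) show how little the numbers moved at that other site. The data say nothing direct about the new change, so the range must stay wide. The expected step is no larger than the scatter (a 1.4-fold higher number from compound 1 to compound 4 (0.13 log units; within the scatter)) in this assay for now. Compound 4 is therefore estimated at 3000 nM within an expected range of 1000 nM to 9000 nM until it is measured.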

Compound 4, half-maximal inhibitory concentration: 1100 nM
For compound 4 the middle estimate is 2.7-fold (0.44 log units) above the measured one; low and high end bracket the measured number.
By their numbers in this assay, from the lowest: compounds 4, 3, 2 and 1 (each within the scatter of the next).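

Among the compounds shown here, this is the first direct reading at this position: in this assay the change to dimethylamino gives a 2.0-fold lower number from compound 1 to compound 4 (0.30 log units; within the scatter) and so cannot be told apart from no change. Propylamino carries 1 hydrogen-bond donor and dimethylamino 0, so with the amide end of compound 1, neither losing that donor nor going from 4 heavy atoms to 3 moves the number beyond the scatter. No supporting measurement bears on the reason for this result.

The compounds shown leave open how a longer chain such as hexylamino, or a cyclic amine such as morpholine, would read on this aromatic carbon. They also leave open whether dimethylamino gives a similar result with the amide end of compound 3.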